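Chloro on the pendant phenyl of a tetrabromobenzimidazole-tetrazole

A few compounds are considered here, and "the series" means these few. Any claim that something is new, unique, unknown or untested is made for them only; others in the source may bear on it.

Of the compounds shown here, three in a common series have been tested in a functional assay on CCRF-CEM cells (Homo sapiens) for cytotoxicity, read by MTT assay, with a stated time of 24 h, tested at 50 uM; on this read-out lower numbers stand for a stronger effect and higher numbers for a weaker effect at the one concentration tested. Compound 1 `Brc1c(Br)c(Br)c2c(ncn2CCCn2nnc(-c3ccccc3)n2)c1Br` gives 4%. Compound 2 `Clc1ccccc1-c1nnn(CCCn2cnc3c(Br)c(Br)c(Br)c(Br)c32)n1`, which carries a chloro group on its phenyl ring, gives 68%. Compound 3 `Brc1c(Br)c(Br)c2c(ncn2CCCn2nnnc2-c2ccccc2)c1Br`, in which the phenyl ring sits on the other position of the tetrazole, gives 2%; this is the lowest of the three numbers, with compound 1 within the scatter of it and compound 2 far above it.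

Compound 4 `Clc1ccccc1-c1nnnn1CCCn1cnc2c(Br)c(Br)c(Br)c(Br)c21` has not yet been measured. It differs from compound 3 by chloro in place of hydrogen on an aromatic carbon, the place being an aromatic carbon of the six-membered carbon-only ring, ortho to a large group.

Going by the values given here, the one measured step that bears on this change is a number 64 percentage points higher from compound 1 to compound 2 (beyond the scatter). That pair carries the same replacement on the same kind of ring, differing from the present pair only in how the tetrazole is joined. A step of similar direction is therefore expected for compound 4, namely a number 56 percentage points higher from compound 3 to compound 4 (beyond the scatter) in this assay . On that basis compound 4 is expected to give 58%, with a range from 25% to 82%.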

Compound 4, a percentage reported as inhibition, at one concentration (the size of the read-out at that concentration, not a potency): 2%
Estimate against measurement, compound 4: 56 percentage points above; the measured number lies below the stated range.
By their numbers in this assay, from the lowest: compounds 3, 4 and 1 (each within the scatter of the next); then compound 2.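

In this assay, chloro in place of hydrogen on the phenyl ring of the core of compound 3 gives no change at the digits printed from compound 3 to compound 4 (within the scatter). The large step seen with the same replacement in the other pair does not carry over, so what this change does depends on the core that carries it: the same change on two cores in this assay, a number 64 percentage points higher (beyond the scatter) from compound 1 to compound 2 and no change at the digits printed (within the scatter) from compound 3 to compound 4, 64 percentage points apart, beyond the scatter of two such steps. On the core of compound 3, then, chloro on this aromatic carbon, ortho to a large group, leaves the number as low as it was with hydrogen, and among the four compounds only compound 2 stands apart from the rest.

Two pairs cannot tell why the two cores answer so differently, nor whether a fluoro, a methoxy or an amine on the same carbon would separate them in the same way. Going by these compounds, it also remains open whether chloro on another carbon of the phenyl ring, or a longer chain between the tetrazole and the core, would keep or remove the gap between the two steps.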